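Swapping cyclopropyl for bromo on a kinase inhibitor core

A few compounds are considered here, and "the series" means these few. Any claim that something is new, unique, unknown or untested is made for them only; others in the source may bear on it.

Measured compounds:
- compound 1 `CC(=O)N1CCC(C(=O)NCCCNc2nc(Nc3cccc(F)c3)ncc2Br)CC1`: 430 nM
- compound 2 `COCCC(=O)NCCCNc1nc(Nc2cccc(F)c2)ncc1Br`: 60 nM
- compound 3 `O=C(NCCCNc1nc(Nc2cccc(F)c2)ncc1C1CC1)c1cccs1`: 110 nM

These three compounds share a core and were tested in an assay on isolated protein for inhibition of serine/threonine-protein kinase TBK1 (Homo sapiens); a lower number here means a stronger inhibitor, a higher number a weaker inhibitor. Compound 3 gives 110 nM, the second highest of the three numbers; it sits within the scatter of compound 2 at 60 nM, and compound 1 at 430 nM lies beyond the scatter above it. Within the data shown here, the one measured step, a 7.2-fold lower number from compound 1 to compound 2 (0.86 log units; beyond the scatter), concerns the amide end of the molecule and is modest.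

Compound 4 `O=C(NCCCNc1nc(Nc2cccc(F)c2)ncc1Br)c1cccs1` differs from compound 3 in one place: bromo in place of cyclopropyl on an aromatic carbon. Among the measured compounds shown here, no measured step changes this position, so there is no direct precedent. Compounds 1 and 2 both carry bromo there and are of comparable strength to compound 3, which suggests the change is tolerated. The expected step of a 1.6-fold lower number from compound 3 to compound 4 (0.20 log units; within the scatter) is therefore small, toward a slightly lower number, with wide uncertainty. Compound 4 is estimated at 70 nM, in a range from 25 nM to 200 nM.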

Compound 4, half-maximal inhibitory concentration: 9 nM
Beside the measured number, compound 4's estimate is 7.8-fold (0.89 log units) above it, outside the stated range (below it).
By their numbers in this assay, from the lowest: compound 4; then compounds 2 and 3 (each within the scatter of the next); then compound 1.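

In this assay, among these compounds, the first direct reading of this position is a 12-fold lower number from compound 3 to compound 4 (1.09 log units; beyond the scatter) and it shows that bromo in place of cyclopropyl on this aromatic carbon is a large change, not the tolerated swap the earlier compounds seemed to allow. With bromo held fixed, the amide end also counts: thiophen-2-yl in place of 2-methoxyethyl gives a 6.7-fold lower number from compound 2 to compound 4 (0.82 log units; beyond the scatter) and thiophen-2-yl in place of 1-acetylpiperidin-4-yl gives a 48-fold lower number from compound 1 to compound 4 (1.68 log units; beyond the scatter) so this acyl group sits at the low end of the numbers among the bromo compounds. Nothing available explains why either change lowers the number.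

As far as these compounds go, only bromo and cyclopropyl have been read at this position, so how chloro, methyl or a nitrile would behave there stays open. From the compounds shown here alone, whether bromo brings a similar drop with other amide ends, such as 2-methoxyethyl, also remains open.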